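Adding an Amino Group to a Weak Inhibitor

The source may hold more compounds than are shown below. What is called first, only, known or untested is meant among the compounds shown, and "the series" means these compounds.

Only a little is known about this small set of compounds, and most of it points to weak inhibition. In a functional assay on Vero cells (Chlorocebus sabaeus) for inhibition (a lower number here means a stronger inhibitor, a higher number a weaker inhibitor), compound 1 `Nc1nc(O)c2ncn([C@@H]3CS[C@@H](CO)O3)c2n1` gives 63600 nM as its measured value. Compound 2 `Nc1nc(Cl)c2ncn([C@H]3CS[C@@H](CO)O3)c2n1` gives > 100000 nM and this is a limit of the assay, not a number. Going by these compounds, compound 3 `OC[C@H]1O[C@@H](n2cnc3c(O)ncnc32)CS1` gives > 100000 nM and this too is only a limit, so its true strength is unknown.

The next compound to consider is compound 4 `Nc1nc(O)c2ncn([C@H]3CS[C@@H](CO)O3)c2n1`. It is related to compound 3 by one change: amino in place of hydrogen on an aromatic carbon with amino in place of hydrogen on an aromatic carbon, between two ring nitrogen atoms.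

Going by the values given here, no measured pair of compounds shows what this change does, so the expectation is loose. Among the compounds with values here, compound 1 at 63600 nM in this assay is the only compound here to give a number, and that suggests a value for compound 4 is within reach. A modest step toward stronger inhibition is expected, and the estimated step of an at least 2.0-fold lower number from compound 3 to compound 4 (0.30 log units; that floor lies within the scatter) is no more than that. Compound 4 may still end at the limit of the assay. Compound 4 is estimated at 50000 nM with an expected range from 10000 nM to 150000 nM in this test.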

Compound 4, half-maximal inhibitory concentration: > 100000 nM
Compound 4 was reported as a limit; the forecaster's own chance of this, stated with the estimate: 45%; middle value at least 2.0-fold (0.30 log units) from the limit.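

In this assay compound 4 gives > 100000 nM, which is a limit of the assay, so amino in place of hydrogen, between two ring nitrogen atoms, does not bring this compound to a measured number. The steps to compound 4 from compound 2 and from compound 3 cannot be read, since both ends of each step are limits: the limit of > 100000 nM in this assay, at which 3 of the 4 values shown sit. Going by these compounds alone, the only readable comparison is an at least 1.5-fold higher number from compound 1 to compound 4 (0.19 log units; that floor lies within the scatter), so a change of configuration alone may separate these two compounds, although that floor does not establish a real difference: the fact that compounds 1 and 4 differ only in the configuration as drawn.

Going by these compounds, whether the amino group changes inhibition at all remains open, since the true strengths of compound 3 and compound 4 are both hidden behind limits. It is also unknown how a methylamino group or a fluorine atom in the same place would read out in this assay, or whether either would give a measured value on this core.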